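Ethyl to Isopropyl Ester on a Calcium Channel Blocker

The source may hold more compounds than are shown below. What is called first, only, known or untested is meant among the compounds shown, and "the series" means these compounds.

Compound 1 `CCOC(=O)C1=C(C)NC(C)=C(C(=O)OCC)C1c1[nH]c(CC)nc1Cl`: 0.158 nM
Compound 2 `CCc1nc(Cl)c(C2C(C(=O)OC)=C(C)NC(C)=C2C(=O)OCc2ccccc2)[nH]1`: 1.75 nM
Compound 3 `CCc1nc(Cl)c(C2C(C(=O)OC3CCCCC3)=C(C)NC(C)=C2C(=O)OC2CCCCC2)[nH]1`: 0.132 nM

All three share one core and were tested in an assay on ileum for inhibition of Voltage-dependent L-type calcium channel subunit alpha-1C (Cavia porcellus); a higher number here means a weaker inhibitor, a lower number a stronger inhibitor. Compound 1 stands second highest of the three numbers; its nearest neighbour is compound 3, whose value lies within the usual scatter of it, and its furthest is compound 2, whose higher value lies beyond the scatter. Compound 4 `CCOC(=O)C1=C(C)NC(C)=C(C(=O)OC(C)C)C1c1[nH]c(CC)nc1Cl` differs from compound 1 by methyl in place of hydrogen on a saturated chain carbon bound to an oxygen next to a carbonyl group and a saturated chain carbon. Among the measured compounds shown here, no measured pair isolates such a change, so nothing measured points either way. Because compound 1 at 0.158 nM and compound 3 at 0.132 nM sit within the scatter of each other despite very different ester groups, the step of a 1.0-fold higher number from compound 1 to compound 4 (0.01 log units; within the scatter) is expected to stay within the scatter, with no direction. Compound 4 is estimated at 0.16 nM, between 0.06 nM and 0.45 nM.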

Compound 4, half-maximal inhibitory concentration: 0.564 nM
Compound 4: the middle estimate sits 3.5-fold (0.55 log units) below what was measured; the whole stated range lies below it.
By their numbers in this assay, from the lowest: compounds 3 and 1 (each within the scatter of the next); then compound 4; then compound 2.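

In this assay, changing ethoxycarbonyl to isopropoxycarbonyl gives a 3.6-fold higher number from compound 1 to compound 4 (0.55 log units; beyond the scatter), so a single added methyl is enough to give a weaker inhibitor, by a modest step beyond the scatter. Among the compounds shown here, this is the first pair here that differs in only one place, and so the first direct reading of a change at this carbon. No supporting measurement is available to explain the shift. As far as these compounds go, whether a longer chain such as propyl, or a carboxylic acid in place of the ester, would move the number in the same direction stays open.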